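Removing a Methyl from the Linker Chain

The source may report more compounds than this note shows. Statements on the series, on what has been measured and on what is new or still open speak of the compounds shown alone.

Within the data shown here, compound 2 `C[C@H](CSc1nonc1/C(=N/O)Nc1ccc(F)c(Br)c1)NC(=O)CS(N)(=O)=O` gives 12 nM in an assay for inhibition of Indoleamine 2,3-dioxygenase 1 (Homo sapiens), read by fluorescence, with a stated time of 24 h (a lower number here means a stronger inhibitor, a higher number a weaker inhibitor), the lower of the two numbers so far, although compound 1 `NS(=O)(=O)CC(=O)NCCSc1nonc1/C(=N/O)Nc1ccc(F)c(C(F)F)c1`, giving 13 nM in this assay, sits within the scatter of it. Compound 3 `NS(=O)(=O)CC(=O)NCCSc1nonc1/C(=N/O)Nc1ccc(F)c(Br)c1` differs from compound 2 by hydrogen in place of methyl on a saturated chain carbon bound to an amide-type nitrogen and a saturated chain carbon. Among the measured compounds shown here, no measured pair isolates this change, so the step in this assay is expected to be none beyond the scatter, in either direction. Compound 3 is therefore estimated at 13 nM, within 6 nM to 28 nM, which means an expected step of a 1.1-fold higher number from compound 2 to compound 3 (0.03 log units; within the scatter).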

Compound 3, half-maximal inhibitory concentration: 12 nM
The estimate for compound 3 lay 1.1-fold (0.03 log units) above the measured number; measured number inside the range.
By their numbers in this assay, from the lowest: compounds 2, 3 and 1 (each within the scatter of the next).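

In this assay, hydrogen in place of methyl on the saturated chain carbon gives no change at the digits printed from compound 2 to compound 3 (within the scatter), so at these values the methyl is not required. Among these compounds, compound 3 also isolates the aromatic carbon for the first time: bromo in place of difluoromethyl gives a 1.1-fold lower number from compound 1 to compound 3 (0.03 log units; within the scatter), and the two groups are not told apart. No available evidence bears on either step. Going by these compounds, whether an ethyl or hydroxyl group on that chain carbon would also stay within the scatter remains open. So does the outcome of a chloro or trifluoromethyl group on the aromatic carbon.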